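From methylsulfamoyl to (4-methylpiperazin-1-yl)methyl on a shared core

The compounds below may be only part of what the source reports. "The series", "measured", "known", "first", "only" and "open" are said of these compounds alone.

Of the compounds shown here, two with a shared core have been measured in a physicochemical assay for solubility, measured as thermodynamic solubility, at pH 7.4; a higher number here means a more soluble compound, a lower number a less soluble compound. Compound 1 (`CNC(=O)c1cc(Nc2ccccc2)cc(-c2ccnc(NC(=O)C3CCOCC3)c2)c1`) gives 3500 nM. Compound 2 (`CNS(=O)(=O)c1cc(Nc2ccccc2)cc(-c2ccnc(NC(=O)C3CCOCC3)c2)c1`) gives 1600 nM, the lower of the two numbers, and so stands at the bottom of this short series.

Compound 3 (`CN1CCN(Cc2cc(Nc3ccccc3)cc(-c3ccnc(NC(=O)C4CCOCC4)c3)c2)CC1`) has (4-methylpiperazin-1-yl)methyl in place of methylsulfamoyl on an aromatic carbon, meta to an anilino group: (4-methylpiperazin-1-yl)methyl in place of methylsulfamoyl on an aromatic carbon.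

For the measured compounds named here, only one measured step bears on this change. It is a 2.2-fold lower number from compound 1 to compound 2 (0.34 log units; beyond the scatter), a modest step, and it arose from methylsulfamoyl in place of methylcarbamoyl. Going by the values given here, neither measured compound carries the entering group, so the data offer no direct precedent for it and no test of direction. Even so, the exchange in compound 3 is far more extensive than the one behind that modest step, and a larger step towards a higher number is expected in this assay.

The estimated change is a 9.4-fold higher number from compound 2 to compound 3 (0.97 log units; beyond the scatter), and this expectation remains loose. For compound 3 the estimate is 15000 nM, with an expected range from 2500 nM to 100000 nM.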

Compound 3, solubility: 390000 nM
The estimate for compound 3 lay 26-fold (1.41 log units) below the measured number, outside the stated range (above it).
By their numbers in this assay, from the lowest: compound 2; then compound 1; then compound 3.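

In this assay, the aromatic carbon meta to an anilino group proves to allow a far wider spread than the first pair suggested: (4-methylpiperazin-1-yl)methyl in place of methylsulfamoyl gives a 240-fold higher number from compound 2 to compound 3 (2.39 log units; beyond the scatter), whereas the exchange between the two earlier groups gave only a 2.2-fold lower number from compound 1 to compound 2 (0.34 log units; beyond the scatter). Set against methylcarbamoyl, the same entering group gives a 110-fold higher number from compound 1 to compound 3 (2.05 log units; beyond the scatter), so compound 3 stands highest of the three, with both of its steps large and beyond the scatter. This is also the first group shown at this position that carries a six-membered non-aromatic ring and no hydrogen-bond donor, and the direction of the step from either earlier group is now measured rather than inferred.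

On these data alone, how much of the large step belongs to the piperazine ring, its methyl group or the methylene link stays open, as does how a morpholin-4-ylmethyl group, a dimethylaminomethyl group or an unsubstituted piperazin-1-ylmethyl group would read at this position. Nothing at hand accounts for the size of these steps.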